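Compound 3 to Compound 4: Dropping the Amide-Type Nitrogen

A few compounds are considered here, and "the series" means these few. Any claim that something is new, unique, unknown or untested is made for them only; others in the source may bear on it.

Compound 3 `COc1cc(Cl)cc(-c2nn(-c3cccc(NC(=O)Nc4cccc(C(F)(F)F)c4)c3)cc2-c2ccncc2)c1` gives 100% in a functional assay on COLO 205 cells (Homo sapiens) for inhibition, read by sulforhodamine B assay, with a stated time of 48 h, tested at 0.01 uM (on this read-out higher numbers stand for a weaker effect at the one concentration tested and lower numbers for a stronger effect), numerically the highest of the three numbers, though compound 2 `COc1cc(Cl)cc(-c2nn(-c3cccc(NC(=O)Nc4ccc(Cl)c(Cl)c4)c3)cc2-c2ccncc2)c1` with 99% and compound 1 `COc1cc(Cl)cc(-c2nn(-c3cccc(NC(=O)Nc4ccc(Cl)c(C(F)(F)F)c4)c3)cc2-c2ccncc2)c1` with 97% both lie within the scatter of it. The measured steps of a number 2 percentage points higher from compound 1 to compound 2 (within the scatter), a number 3 percentage points higher from compound 1 to compound 3 (within the scatter) and a number 1 percentage points higher from compound 2 to compound 3 (within the scatter) all concern the aryl group attached to the amide-type nitrogen, and none reaches beyond the scatter. Compound 4 `COc1cc(Cl)cc(-c2nn(-c3cccc(NC(=O)c4cccc(C(F)(F)F)c4)c3)cc2-c2ccncc2)c1` differs from compound 3 by 3-(trifluoromethyl)phenyl in place of (3-(trifluoromethyl)phenyl)amino on a carbonyl carbon. Among the measured compounds shown here, no measured step touches this carbonyl carbon, so the expectation rests only on how little the three compounds move in this assay. Compound 4 is therefore expected to show a number 2 percentage points lower from compound 3 to compound 4 (within the scatter). Compound 4 is estimated at 98%, within a range from 90% to 104%.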

Compound 4, a percentage reported as activity, at one concentration (the size of the read-out at that concentration, not a potency): 108%
Estimate against measurement, compound 4: 10 percentage points below; the whole stated range lies below it.
By their numbers in this assay, from the lowest: compounds 1, 2, 3 and 4 (each within the scatter of the next, the first and the last beyond it).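

Among the compounds shown here, on the carbonyl carbon, 3-(trifluoromethyl)phenyl in place of the arylamino groups gives a number 8 percentage points higher from compound 3 to compound 4 (within the scatter) and a number 9 percentage points higher from compound 2 to compound 4 (within the scatter), while a number 11 percentage points higher from compound 1 to compound 4 (beyond the scatter) is the only step in this set to pass the scatter, and it is modest. In this assay, the direct counterpart of compound 4, compound 3, therefore stays within the scatter of it, although the amide-type nitrogen has gone. Nothing measured here offers an explanation for these numbers. On these data alone, whether a benzylamino group or a morpholine on this carbonyl carbon would move the number remains open. So does the reading at any other concentration.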